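A few compounds are considered here, and "the series" means these few. Any claim that something is new, unique, unknown or untested is made for them only; others in the source may bear on it.

In an assay on isolated protein for inhibition of matrix metalloproteinase-9 (Homo sapiens), read by fluorescence, with stated times of 1 h and 15 min (on this read-out higher numbers stand for weaker inhibition and lower numbers for stronger inhibition), compound 3 `COc1ccc(Oc2ccc(S(=O)(=O)N[C@@H]3CC=CCN(O)C3=O)cc2)cc1` gives 1 nM. Among the three measured compounds this number stands second highest. Within the data shown here, compound 1 `O=C1[C@H](NS(=O)(=O)c2ccc(Oc3ccc(Cl)cc3)cc2)CC=CCN1O` gives 0.58 nM, and the single change separating these two amounts to a 1.7-fold higher number from compound 1 to compound 3 (0.24 log units; within the scatter). Among the measured compounds shown here, compound 2 `O=C(N[C@@H]1CC=CCN(O)C1=O)c1ccc(Oc2ccc(Cl)cc2)cc1` gives 5090 nM, a number far beyond the scatter from compound 3; no single-change step connects it to compound 3, so only the two values themselves can be compared.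

Compound 4 `O=C1[C@H](NS(=O)(=O)c2ccc(Oc3ccccn3)cc2)CC=CCN1O` has not yet been measured. It differs from compound 3 by pyridin-2-yl in place of 4-methoxyphenyl on an oxygen on an aromatic ring. For the measured compounds named here, only one measured step touches the same part of the molecule: a 1.7-fold higher number from compound 1 to compound 3 (0.24 log units; within the scatter), which swapped one substituent on the outer ring and stayed within the scatter. Going by the values given here, that step suggests the outer ring tolerates some variation, but no step shows the ring itself replaced by one carrying a ring nitrogen with the methoxy gone, so the outcome is less certain. A modest rise in the number, or none beyond the scatter, is the expectation for compound 4, and the expected step is a 3.0-fold higher number from compound 3 to compound 4 (0.48 log units; beyond the scatter). Compound 4 is therefore estimated to give 3 nM, with a likely range from 0.8 nM to 12 nM.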

Compound 4, half-maximal inhibitory concentration: 23 nM
Estimate against measurement, compound 4: 7.7-fold (0.88 log units) below, and the stated range ends below it.
By their numbers in this assay, from the lowest: compounds 1 and 3 (each within the scatter of the next); then compound 4; then compound 2.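

In this assay, among these compounds, the group on the oxygen turns out to matter far more than the one earlier change there suggested, where methoxy in place of chloro gave only a 1.7-fold higher number from compound 1 to compound 3 (0.24 log units; within the scatter). Replacing the whole outer ring is a different matter: pyridin-2-yl in place of 4-methoxyphenyl gives a 23-fold higher number from compound 3 to compound 4 (1.36 log units; beyond the scatter), and pyridin-2-yl in place of 4-chlorophenyl gives a 40-fold higher number from compound 1 to compound 4 (1.60 log units; beyond the scatter). So the 4-chlorophenyl and 4-methoxyphenyl compounds sit within the scatter of each other while the pyridin-2-yl compound stands clearly apart from both, which shows that this position tolerates a change of substituent on the ring but not every change of the ring itself.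

This swap makes two changes at once, since the ring gains a nitrogen and loses its substituent, so a plain phenyl group and a pyridine ring carrying a methoxy group would be needed to tell which change accounts for the loss. The data shown offer no measurement that explains the size of this step.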